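Moving the halogen on the phenoxy group: compound 3

The source may report more compounds than this note shows. Statements on the series, on what has been measured and on what is new or still open speak of the compounds shown alone.

Among the two compounds measured in a functional assay on CHO cells for agonist activity at prostaglandin E2 receptor EP2 subtype (Homo sapiens), read by HTRF and cAMP accumulation, with a stated time of 30 min (a higher number here means that more compound is needed for the effect, a lower number that less compound is needed), compound 2, with the structure `O=C(O)c1csc([C@H]2CC[C@@H]3[C@@H](COc4cccc(Cl)c4)[C@H](O)C[C@@H]3O2)n1`, gives 6.5 nM, the lowest number of the pair. Going by the values given here, its only neighbour is compound 1, with the structure `O=C(O)c1csc([C@H]2CC[C@@H]3[C@@H](COc4ccccc4F)[C@H](O)C[C@@H]3O2)n1`, which in this assay gives 23 nM. Among the compounds with values here, the one step connecting them, a 3.5-fold lower number from compound 1 to compound 2 (0.55 log units; beyond the scatter), shows that exchanging the aromatic ring on the oxygen on the saturated carbon shifts the result by a modest but real amount.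

Compound 3, with the structure `O=C(O)c1csc([C@H]2CC[C@@H]3[C@@H](COc4ccc(F)cc4)[C@H](O)C[C@@H]3O2)n1`, has not been measured. It differs from compound 2 by 4-fluorophenyl in place of 3-chlorophenyl on an oxygen on a saturated carbon. Within the data shown here, no measured step covers this exact exchange; the step from compound 1 to compound 2 only shows that a different halogenated phenyl on this oxygen can move the number by the size seen there. A shift of comparable size in either direction is therefore plausible, with no firm direction.

Compound 3 is estimated at 12 nM in this assay, within a range of 4 nM to 40 nM, which would mean a step of a 1.8-fold higher number from compound 2 to compound 3 (0.27 log units; within the scatter).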

Compound 3, half-maximal effective concentration: 7 nM
Compound 3: middle estimate off by 1.7-fold (0.23 log units), on the high side; low and high end bracket the measured number.
By their numbers in this assay, from the lowest: compounds 2 and 3 (each within the scatter of the next); then compound 1.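

In this assay, exchanging 3-chlorophenyl for 4-fluorophenyl gives a 1.1-fold higher number from compound 2 to compound 3 (0.03 log units; within the scatter), so these two groups cannot be told apart here, although they differ in both the halogen and where it sits on the ring. Going by these compounds alone, exchanging 2-fluorophenyl for 4-fluorophenyl gives a 3.3-fold lower number from compound 1 to compound 3 (0.52 log units; beyond the scatter), and this is the first step to keep the halogen the same and change only its place on the ring, whereas the earlier step changed both at once. Chlorine is therefore not required to reach the level of compound 2, and among these three compounds it is compound 1, with its 2-fluorophenyl group, that stands apart.

The three compounds leave open how a plain phenyl, a 3-fluorophenyl or a 4-chlorophenyl group would compare, so the effects of the halogen and its place on the ring cannot yet be fully separated. Nothing available here explains why the place of the fluorine changes the number.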